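Working notes on one pending analogue in the series

The compounds below may be only part of what the source reports. "The series", "measured", "known", "first", "only" and "open" are said of these compounds alone.

Measured compounds:
compound 1, `COc1cc(/C=C/c2nc(O)nc(NC(C)C)n2)cc(OC)c1OC`
compound 2, `C(=C/c1ccco1)\c1nc(NC2CC2)c2sccc2n1`
compound 3, `COc1cc(/C=C/c2nc(N3CCCC3)c3sccc3n2)cc(OC)c1OC`

In a functional assay on L02 cells (Homo sapiens) for inhibition, read by Griess assay, with stated times of 1 h and 24 h (on this read-out lower numbers stand for stronger inhibition and higher numbers for weaker inhibition), compound 1 gives < 40000 nM, which is a limit of the assay (the limit of < 40000 nM in this assay, at which 1 of the 3 values shown sits). Compound 2 gives > 1000000 nM, also a limit (the limit of > 1000000 nM in this assay, at which 1 of the 3 values shown sits). Compound 3 gives 681000 nM, the only number shown among the three. For the measured compounds named here, no step between measured compounds can be computed here.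

Compound 4 is `COc1cc(/C=C/c2nc(Nc3ccc(C(F)(F)F)cc3)c3sccc3n2)cc(OC)c1OC`; it differs from compound 3 by (4-(trifluoromethyl)phenyl)amino in place of pyrrolidin-1-yl on an aromatic carbon. Nothing measured bears directly on this change, so any expectation is loose. Compound 4 is expected at 300000 nM, within 60000 nM to 1500000 nM, implying an expected step of a 2.3-fold lower number from compound 3 to compound 4 (0.36 log units; beyond the scatter) that may not exceed the scatter.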

Compound 4, half-maximal inhibitory concentration: 436000 nM
Estimate against measurement, compound 4: 1.5-fold (0.16 log units) below; low and high end bracket the measured number.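

In this assay, (4-(trifluoromethyl)phenyl)amino in place of pyrrolidin-1-yl on an aromatic carbon next to the ring nitrogen gives a 1.6-fold lower number from compound 3 to compound 4 (0.19 log units; within the scatter). For the compounds shown here, this is the first step that can be read, and it shows that a larger group, one that adds a hydrogen-bond donor and an aromatic ring, leaves the read-out within the scatter at this position. Nothing measured here accounts for this step. From the compounds shown here alone, whether a morpholin-4-yl or benzylamino group at this position would give a step beyond the scatter stays open. So does the effect of a carboxylic acid in place of trifluoromethyl.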